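The compounds below may be only part of what the source reports. "The series", "measured", "known", "first", "only" and "open" are said of these compounds alone.

Measured so far:
- compound 1, `CC(C)n1cc(-c2ccnc3[nH]c(C4CCN(CC(=O)N5CCCCC5)CC4)cc23)ccc1=O`: 1.7 h
- compound 2, `COc1cc(C(=O)N2CCCC2)ccc1-c1ccnc2[nH]c(C3CCNCC3)cc12`: 11 h
- compound 3, `COc1cc(F)ccc1-c1ccnc2[nH]c([C@H]3CC[C@H](NC(C)=O)CC3)cc12`: 1.2 h

In an ADME assay (Rattus norvegicus, strain Han-wistar) for metabolic stability, at a dose of 1.5 umol/kg by the intravenous route (on this read-out lower numbers stand for a shorter-lived compound and higher numbers for a longer-lived compound), compound 1 stands second highest of these three numbers. Its nearest neighbour is compound 3, whose number lies within the usual scatter of it, while compound 2 gives the number furthest from it, a gap beyond the scatter. Compound 4, `CNC(=O)CN1CCC(c2cc3c(-c4ccc(=O)n(C(C)C)c4)ccnc3[nH]2)CC1`, has not yet been measured. It differs from compound 1 in one place: methylamino in place of piperidin-1-yl on a carbonyl carbon. Going by the values given here, no pair of measured compounds shows this same change, so its effect on the half-life is unknown here. The expected step is a 1.3-fold higher number from compound 1 to compound 4 (0.11 log units; within the scatter), small and most likely within the scatter, if anything toward a slightly longer-lived compound. Compound 4 is therefore estimated at 2.2 h, within a range of 0.9 h to 5 h.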

Compound 4, half-life: 0.7 h
Beside the measured number, compound 4's estimate is 3.1-fold (0.50 log units) above it; the whole stated range lies above it.
By their numbers in this assay, from the lowest: compounds 4, 3 and 1 (each within the scatter of the next, the first and the last beyond it); then compound 2.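

Replacing piperidin-1-yl with methylamino on this carbonyl carbon gives a 2.4-fold lower number from compound 1 to compound 4 (0.39 log units; beyond the scatter) in this assay. This modest step shows that the group at this position can change the half-life, and that here the piperidine ring gives the longer-lived compound. Nothing shown explains the shorter half-life. 

As far as these compounds go, it remains open whether the difference follows the loss of the ring or the gain of the amide hydrogen. Dimethylamino on the same carbonyl carbon, which has no ring and no amide hydrogen, could help separate those two changes.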